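The source may report more compounds than this note shows. Statements on the series, on what has been measured and on what is new or still open speak of the compounds shown alone.

Compound 1 `Nc1ccccc1NC(=O)CCCNCC(=O)Nc1cccc(Cl)c1`: > 100000 nM
Compound 2 `Nc1ccccc1NC(=O)CCCNCC(=O)Nc1ccc(Br)cc1`: > 100000 nM
Compound 3 `Nc1ccccc1NC(=O)CCCNCC(=O)Nc1cc(Cl)ccc1Cl`: > 100000 nM

In a functional assay on HCT-116 cells (Homo sapiens) for inhibition, read by MTT assay, with a stated time of 2 days (on this read-out higher numbers stand for lower toxicity in this test and lower numbers for higher toxicity in this test), compound 3 stands at > 100000 nM, a limit and not a number. Within the data shown here, it shares this position with the other two compounds, and the series so far shows (the limit of > 100000 nM in this assay, at which 3 of the 3 values shown sit).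

Compound 4 `Nc1ccccc1NC(=O)CCCNCC(=O)Nc1ccccc1Cl` differs from compound 3 by a single change, hydrogen in place of chloro on an aromatic carbon, meta to a large group and para to a chloro group: hydrogen in place of chloro on an aromatic carbon. Cut one bond further out, this reads 2,5-dichlorophenyl to 2-chlorophenyl.

The closest measured change runs the same way in reverse, as a step that the two limits leave unreadable from compound 1 to compound 3. The other two measured changes on the amide-type nitrogen are a step that the two limits leave unreadable from compound 1 to compound 2 and a step that the two limits leave unreadable from compound 2 to compound 3. None of these gives a size to carry over.

No step beyond the scatter is expected in this assay because the limit of > 100000 nM in this assay, at which 3 of the 3 values shown sit, covers compound 1, compound 2 and compound 3 alike. The estimated step is a number no higher from compound 3 to compound 4 (the limit leaves the size open). Compound 4 is expected at about 100000 nM, with an estimated range of 50000 nM to 200000 nM.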

Compound 4, concentration lethal to 50% of the cells: > 100000 nM
Compound 4 was reported as a limit; the forecaster's own chance of this, stated with the estimate: 90%; the middle value lies on the limit itself.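

In this assay compound 4 gives > 100000 nM, a limit and not a number. Among these compounds, no step among compound 1, compound 2, compound 3 and compound 4 can be read: the limit of > 100000 nM in this assay, at which 4 of the 4 values shown sit. The compounds shown leave open whether any of the four differs from another in this assay, and by how much.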